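This account rests on a few compounds, and the source may have more. Where it says the series, first, only, none or still open, it means among the compounds named here.

Compound 1 `COc1ccc(-c2noc(-c3ccccc3)n2)cc1OC1CCCC1` was tested in a functional assay on MDA-MB-231 cells (Homo sapiens) for antiproliferative activity, read by MTT assay, with a stated time of 24 h (on this read-out higher numbers stand for weaker inhibition and lower numbers for stronger inhibition), where compound 1 gives > 1000000 nM, which is a limit of the assay rather than a number. Compound 2 `COc1ccc(-c2noc(-c3ccc(F)cc3)n2)cc1O` in this assay also gives only a limit, > 1000000 nM. Compound 3 `COc1cc(-c2noc(-c3ccncc3)n2)ccc1OCc1ccccc1` in this assay gives > 1000000 nM, again a limit. Every value shown thus sits at the limit of > 1000000 nM in this assay, at which 3 of the 3 values shown sit, so where compound 1 stands relative to the other two cannot be told. Compound 4 `COc1ccc(-c2noc(C3CCNCC3)n2)cc1OC1CCCC1` differs from compound 1 by piperidin-4-yl in place of phenyl on an aromatic carbon. Within the data shown here, with no measured step of this kind to lean on, the change is expected to bring no step beyond the scatter in this assay. Compound 4 is therefore expected to give an estimated 1000000 nM, ranging from 200000 nM to 5000000 nM, an expected step of a number no higher from compound 1 to compound 4 (the limit leaves the size open).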

Compound 4, half-maximal inhibitory concentration: 370 nM
Compound 4: middle estimate off by 2700-fold (3.43 log units), on the high side, outside the stated range (below it).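

In this assay, piperidin-4-yl in place of phenyl on this aromatic carbon of the shared core gives an at least 2700-fold lower number from compound 1 to compound 4 (3.43 log units; beyond the scatter). The value of compound 1, > 1000000 nM, is a limit and not a number. This position is therefore one where a single change moves the read-out from the limit to a measured number, the only such case among the compounds shown: the limit of > 1000000 nM in this assay, at which 3 of the 4 values shown sit.

As far as these compounds go, it remains open whether the ring nitrogen or the non-aromatic ring carries this step. Cyclohexyl, which has no ring nitrogen, and an open-chain amine such as aminoethyl would help to separate the two.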